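Cytotoxicity notes on the series: the step to compound 3

The compounds below may be only part of what the source reports. "The series", "measured", "known", "first", "only" and "open" are said of these compounds alone.

Measured compounds:
compound 1, `Cc1nc(C)c(Cn2ncc3c(Nc4ccc(OC(F)(F)F)cc4)ncnc32)s1`, > 10000 nM
compound 2, `CC(C)(C)n1ncc2c(Nc3ccc(OC(F)(F)F)cc3)ncnc21`, 7300 nM

In an ADME assay on BaF3 cells (Mus musculus) for cytotoxicity (a lower number here means that less compound is needed, a higher number that more compound is needed for the effect), compound 1 gives > 10000 nM, which is a limit of the assay and not a number. In this assay compound 2 gives 7300 nM, the only number shown in the set. Within the data shown here, the one measured step is an at least 1.3-fold lower number from compound 1 to compound 2 (0.13 log units; that floor lies within the scatter); it rests on the limit of > 10000 nM in this assay, at which 1 of the 2 values shown sits, and says little about direction.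

Compound 3, `FC(F)(F)Oc1ccc(Nc2ncnc3c2cnn3CC2CCOC2)cc1`, is still to be measured in this assay. It differs from compound 2 as (oxolan-3-yl)methyl in place of tert-butyl on an aromatic nitrogen. Among the measured compounds shown here, the only step that bears on the change at this aromatic nitrogen is the one from compound 1 to compound 2, and that one lies within the scatter. Nothing in the series points to a shift beyond the scatter, so the expected step is a 1.1-fold higher number from compound 2 to compound 3 (0.04 log units; within the scatter). Compound 3 is therefore estimated at 8000 nM, with a range from 3000 nM to 20000 nM, and a fair chance that only a limit is reported.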

Compound 3, half-maximal effective concentration: > 10000 nM
Compound 3 ended at the assay's limit (the forecaster's own chance of this, stated with the estimate: 40%); middle value at least 1.2-fold (0.09 log units) away from the limit.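

In this assay compound 3 gives > 10000 nM, which is a limit of the assay and not a number. On this aromatic nitrogen, (oxolan-3-yl)methyl in place of tert-butyl brings in a five-membered non-aromatic ring and a hydrogen-bond acceptor and gives an at least 1.3-fold higher number from compound 2 to compound 3 (0.13 log units; that floor lies within the scatter), so a second group at this position, after the (2,4-dimethyl-1,3-thiazol-5-yl)methyl of compound 1, ends at the limit, and the step between these two limits cannot be read. Compound 2 remains the only compound with a number, and the reading of this position is bounded by: the limit of > 10000 nM in this assay, at which 2 of the 3 values shown sit.

As far as these compounds go, how far compound 1 and compound 3 actually lie from compound 2 stays open. Also open, from the compounds shown here alone, is whether an amine or a carboxylic acid on a chain at this nitrogen would give a number clearly apart from that of compound 2.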